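Ethoxyphenyl for methylphenyl on the shared amine

The source may report more compounds than this note shows. Statements on the series, on what has been measured and on what is new or still open speak of the compounds shown alone.

Measured compounds:
compound 1, `Cc1ccc(NC2=CC(=O)c3c(nc4n3[C@H]3OC[C@@H](O)[C@H]3OC4)C2=O)cc1`: > 4000 nM
compound 2, `O=C1C=C(Nc2cccc(F)c2)C(=O)c2c1nc1n2[C@H]2OC[C@@H](O)[C@H]2OC1`: 5500 nM
compound 3, `O=C1C=C(NC2CCCC2)C(=O)c2c1nc1n2[C@H]2OC[C@@H](O)[C@H]2OC1`: > 16000 nM

In a functional assay on MCF7 cells (Homo sapiens) for inhibition, read by sulforhodamine B assay (on this read-out lower numbers stand for stronger inhibition and higher numbers for weaker inhibition), compound 1 gives only a limit of the assay, > 4000 nM, not a number. Compound 3 likewise gives only a limit, > 16000 nM. Among the compounds with values here, compound 2 is the one compound with a numerical value, 5500 nM. Of the three values, one sits at the limit of > 4000 nM in this assay, at which 1 of the 3 values shown sits, and one at the limit of > 16000 nM in this assay, at which 1 of the 3 values shown sits, so compound 1 cannot be placed against the others beyond saying that its inhibition is no stronger than its limit.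

The step to the unmeasured compound 4, `CCOc1ccccc1NC1=CC(=O)c2c(nc3n2[C@H]2OC[C@@H](O)[C@H]2OC3)C1=O`, is 2-ethoxyphenyl in place of 4-methylphenyl on an amine nitrogen. Within the data shown here, the only measured step, an at least 2.9-fold higher number from compound 2 to compound 3 (0.46 log units; beyond the scatter), swaps an aromatic ring for a saturated ring on the amine nitrogen, which is a different kind of change from the aryl-for-aryl swap in compound 4; it therefore offers no direct guide, and it weakened inhibition, not strengthened it.

Among the measured compounds shown here, with compound 1 known only as a limit and no step of the same kind measured, compound 4 is expected to stay near the weak end, with a change of a step that the limit leaves unreadable from compound 1 to compound 4 from the limit of compound 1 being the best guess. Compound 4 is estimated at 6000 nM, within 2000 nM to 20000 nM, with a real chance that only a limit is reported.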

Compound 4, half-maximal inhibitory concentration: > 4000 nM
Compound 4: a limit, no number; the forecaster's own chance of this, stated with the estimate: 45%; the middle value is on the limit's open side.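

Within the data shown here, compound 1 and compound 4 each give only a limit, not a number, in this assay, so no step between them can be read. The compounds shown leave open how strongly either one inhibits, and whether 2-ethoxyphenyl or 4-methylphenyl on the amine nitrogen gives the stronger inhibition.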